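Two Methylsulfanyl Groups on the Shared Quinone Core

The source may report more compounds than this note shows. Statements on the series, on what has been measured and on what is new or still open speak of the compounds shown alone.

Compound 1 `NC1=C(Cl)C(=O)c2ncccc2C1=O`: > 200000 nM in a functional assay on cells (Neutrophil, Homo sapiens) for inhibition, read by WST assay, with a stated time of 20 min (a higher number here means a weaker inhibitor, a lower number a stronger inhibitor), a limit of the assay.
Compound 2 `C[S+]([O-])C1=C(N)C(=O)c2cccnc2C1=O`: > 200000 nM in this assay, again a limit.
Compound 3 `CSC1=C(N)C(=O)c2cccnc2C1=O`: > 150000 nM in this assay, also a limit.

Compound 3 therefore stands at a limit rather than at a number, as the limit of the limit of > 150000 nM in this assay, at which 1 of the 3 values shown sits, records. The remaining values sit at the other limit, (the limit of > 200000 nM in this assay, at which 2 of the 3 values shown sit). Within the data shown here, none of the measured steps between these three compounds can be read: a step that the two limits leave unreadable from compound 1 to compound 2, a step that the two limits leave unreadable from compound 1 to compound 3 and a step that the two limits leave unreadable from compound 2 to compound 3 all connect one limit to another, so their size is unknown.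

Compound 4 `CSC1=C(SC)C(=O)c2ncccc2C1=O` carries the change (methylsulfanyl in place of amino on a double-bonded ring carbon). Among the measured compounds shown here, no measured step bears readably on this change, and the three neighbours of compound 4 all failed to give a number in this assay. On that basis compound 4 is expected to give a limit as well, and the step that the limit leaves unreadable from compound 3 to compound 4 is expected to be none beyond the scatter. The estimate for compound 4 in this assay is 200000 nM, within the range from 50000 nM to 1000000 nM.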

Compound 4, half-maximal inhibitory concentration: 110 nM
Beside the measured number, compound 4's estimate is 1800-fold (3.26 log units) above it; measured number below the stated range.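

Among these compounds, replacing amino with methylsulfanyl on this double-bonded ring carbon, next to the ring atom that bears a methylsulfanyl group, gives an at least 1300-fold lower number from compound 3 to compound 4 (3.13 log units; beyond the scatter) in this assay, the first step that can be read. Among the compounds shown here, the steps among compound 1, compound 2 and compound 3 cannot be read, so compound 4 is the first to show that the shared core can give a number in this assay rather than a limit, and it does so when methylsulfanyl stands on both of these ring carbons. The size of the step is only a bound, since compound 3 itself stands at a limit and not at a number: the limit of > 150000 nM in this assay, at which 1 of the 4 values shown sits.

The compounds shown leave open whether methylsulfanyl is specifically required at this position, or whether a longer chain such as ethylsulfanyl, or a methoxy group, would give a similar number in this assay. They also leave open whether both methylsulfanyl groups are needed, as a compound carrying methylsulfanyl together with a methyl group or a chlorine atom on the other ring carbon would show.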